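A few compounds are considered here, and "the series" means these few. Any claim that something is new, unique, unknown or untested is made for them only; others in the source may bear on it.

Measured so far in a functional assay on the whole organism (strain Sprague-Dawley) for inhibition, with Rattus norvegicus as the target, read by paw edema, with stated times of 30 min and 3 h, at a dose of 80 mg/kg by the oral route; on this read-out higher numbers stand for more inhibition at the one dose given (going by the name of the read-out) and lower numbers for less inhibition:
compound 1 `O=c1c2ccccc2nc(CO[N+](=O)[O-])n1NS(=O)(=O)c1ccccc1` — 55%
compound 2 `Cc1nc2ccccc2c(=O)n1NS(=O)(=O)c1ccccc1` — 77.3%
compound 3 `Cc1nc2ccccc2c(=O)n1NC(=S)Nc1ccccc1` — 100%

Compound 2 stands second highest of the three numbers in this assay: compound 1 lies below it and compound 3 above it, both gaps beyond the scatter. Compound 4 `Cc1ccc(S(=O)(=O)Nn2c(C)nc3ccccc3c2=O)cc1` differs from compound 2 by methyl in place of hydrogen on an aromatic carbon. Among the measured compounds shown here, the only step recorded so far, a number 22.3 percentage points higher from compound 1 to compound 2 (beyond the scatter), concerns a change on a saturated chain carbon and gives no direct guide to a methyl entering on the aromatic ring. With nothing closer to lean on, the expected step of a number 2.7 percentage points higher from compound 2 to compound 4 (within the scatter) is small, likely within the scatter, in no settled direction. Compound 4 is therefore estimated at 80%, with a range from 62% to 95%.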

Compound 4, a percentage reported as inhibition, in the whole organism at one dose (the size of the read-out at that dose, not a potency): 83.9%
Compound 4: middle estimate off by 3.9 percentage points, on the low side, within the range that was stated.
By their numbers in this assay, from the lowest: compound 1; then compounds 2 and 4 (each within the scatter of the next); then compound 3.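

In this assay, among the compounds shown here, the first change on the aromatic ring gives a number 6.6 percentage points higher from compound 2 to compound 4 (within the scatter), so phenyl to 4-methylphenyl leaves the inhibition at the one dose indistinguishable from the scatter. A single methyl at this place, para to a large group, therefore carries no measurable penalty or gain here. No measurement on hand bears on why this is so. As far as these compounds go, whether an amine, a carboxylic acid or a longer chain at the same place would move the read-out beyond the scatter remains open.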